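The compounds below may be only part of what the source reports. "The series", "measured", "known", "first", "only" and "open" are said of these compounds alone.

Measured so far:
Compound 1 `CC(C)(C)c1cn(C[C@H](O)[C@H]2OC(=O)C(OCc3ccccc3)=C2OCc2ccccc2)nn1` — 28300 nM
Compound 2 `COc1ccccc1-c1cn(C[C@H](O)[C@H]2OC(=O)C(OCc3ccccc3)=C2OCc2ccccc2)nn1` — > 100000 nM (a limit of the assay, not a number)

In a functional assay on HCT-116 cells (Homo sapiens) for antiproliferative activity, read by MTT assay, with a stated time of 72 h (a lower number here means a stronger inhibitor, a higher number a weaker inhibitor), compound 1 gives 28300 nM. For compound 2 this assay reports only a limit, > 100000 nM, so no number is known for it. Among the measured compounds shown here, compound 2 therefore stands at the weak end of the two values shown, and the single measured step, an at least 3.5-fold higher number from compound 1 to compound 2 (0.54 log units; beyond the scatter), is a loss of potency whose full size is not known, as the limit of > 100000 nM in this assay, at which 1 of the 2 values shown sits, marks. Compound 3 `O=C1O[C@H]([C@@H](O)Cn2cc(CNS(=O)(=O)c3ccc(Cl)cc3)nn2)C(OCc2ccccc2)=C1OCc1ccccc1` differs from compound 2 by (((4-chlorophenyl)sulfonyl)amino)methyl in place of 2-methoxyphenyl on an aromatic carbon. For the measured compounds named here, no measured step covers this exchange: the one step known swaps tert-butyl for 2-methoxyphenyl on an aromatic carbon and gives no guide to replacing 2-methoxyphenyl by (((4-chlorophenyl)sulfonyl)amino)methyl. Since compound 2 sits at the limit, any real change in compound 3 can only show as a return to a measurable number; the step expected is an at least 2.0-fold lower number from compound 2 to compound 3 (0.30 log units; that floor lies within the scatter), with wide uncertainty. Compound 3 is estimated at 50000 nM in this assay, within 10000 nM to 150000 nM, with a fair chance that only a limit is again reported.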

Compound 3, half-maximal inhibitory concentration: 8380 nM
For compound 3 the middle estimate is 6.0-fold (0.78 log units) above the measured one, and the stated range ends above it.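

In this assay, the substituent on this aromatic carbon of the five-membered aromatic ring with 3 nitrogen can now be seen to move the number down as well as up: (((4-chlorophenyl)sulfonyl)amino)methyl gives an at least 11-fold lower number from compound 2 to compound 3 (1.07 log units; beyond the scatter) and a 3.4-fold lower number from compound 1 to compound 3 (0.53 log units; beyond the scatter). Both 2-methoxyphenyl and the entering group hold one six-membered aromatic ring of carbon only, so the presence of such a ring does not by itself separate these two results, and the larger entering group is compatible with a measurable number at this place. Compound 2 has only a limit of the assay, > 100000 nM, so the first of these two steps is a floor and its full size remains unknown: the limit of > 100000 nM in this assay, at which 1 of the 3 values shown sits.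

It remains open which part of (((4-chlorophenyl)sulfonyl)amino)methyl goes with the lower number, since the chlorine, the sulfonyl group and the hydrogen on its nitrogen change together in the one group shown. A plain aminomethyl group, an unsubstituted phenylsulfonyl analogue or a carboxamide link would be needed to separate those parts.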